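Undefined stereocentre in compound 3 against compound 2

This account rests on a few compounds, and the source may have more. Where it says the series, first, only, none or still open, it means among the compounds named here.

Compound 1 `Cc1nc(N)sc1CCCNC(=N)NC(=O)C[C@@H](C)c1ccccc1` gives 102 nM in a functional assay on cardiac atrium for agonist activity at histamine H2 receptor (Cavia porcellus); on this read-out higher numbers stand for an effect only at larger amounts of compound and lower numbers for an effect already at smaller amounts. Compound 2 `Cc1nc(N)sc1CCCNC(=N)NC(=O)C[C@@H](C)C1CCCCC1` gives 57.5 nM in this assay, the lower of the two numbers, though the step of a 1.8-fold lower number from compound 1 to compound 2 (0.25 log units; within the scatter) is within the scatter. Compound 3 `Cc1nc(N)sc1CCCNC(=N)NC(=O)CC(C)C1CCCCC1` differs only in that (the two compounds have the same atoms and bonds; at least one stereo element is drawn with a configuration in one of them and without one in the other: 1 of 2 stereo elements differ; a stereocentre at a saturated chain carbon is drawn R in compound 2 and without a configuration in compound 3). No measured step compares a drawn configuration with an undrawn one, so no shown step bears on this change; the expected step in this assay from compound 2 to compound 3 is therefore none beyond the scatter, estimated as a 1.4-fold higher number from compound 2 to compound 3 (0.14 log units; within the scatter). Compound 3 is estimated at 80 nM in this assay, between 40 nM and 170 nM.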

Compound 3, half-maximal effective concentration: 69.2 nM
Beside the measured number, compound 3's estimate is 1.2-fold (0.06 log units) above it; low and high end bracket the measured number.
By their numbers in this assay, from the lowest: compounds 2, 3 and 1 (each within the scatter of the next).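

In this assay, there is a 1.2-fold higher number from compound 2 to compound 3 (0.08 log units; within the scatter), so leaving the configuration at this saturated chain carbon undrawn produced no change beyond the scatter. With the configuration undrawn, the swap between 1-phenylethyl and 1-cyclohexylethyl also stayed inside the scatter, with a 1.5-fold lower number from compound 1 to compound 3 (0.17 log units; within the scatter). The only difference in the first comparison is one of drawn stereochemistry: the fact that one of compounds 2 and 3 is drawn with a defined configuration and the other without, at the place where they differ

The compounds shown leave open how the S configuration at this carbon would read on its own. They also leave open whether a longer chain or an amine on this carbon would stay within the scatter.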